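Swapping Bromine for Iodine on a Benzylidene Side Chain

A few compounds are considered here, and "the series" means these few. Any claim that something is new, unique, unknown or untested is made for them only; others in the source may bear on it.

Compound 2, `CC(CC[C@H]1/C(=C/c2ccc(Br)cc2)CC[C@H]2C(C)(C)CCC[C@]12C)CC(=O)O`, was tested in a functional assay on K562 cells (Homo sapiens) for cytotoxicity, read by MTT assay, with a stated time of 72 h; a lower number here means a stronger inhibitor, a higher number a weaker inhibitor. In this assay compound 2 gives only the assay limit, > 200000 nM. Compound 1, `COc1ccc(/C=C2\CC[C@H]3C(C)(C)CCC[C@]3(C)[C@H]2CCC(C)CC(=O)O)cc1OC`, likewise gives only the limit > 200000 nM in this assay. The step that the two limits leave unreadable from compound 1 to compound 2 therefore cannot be read, as the limit of > 200000 nM in this assay, at which 2 of the 2 values shown sit, shows. Compound 3, `CC(CC[C@H]1/C(=C/c2ccc(I)cc2)CC[C@H]2C(C)(C)CCC[C@]12C)CC(=O)O`, differs from compound 2 by iodo in place of bromo on an aromatic carbon. No readable measured step bears on this change, so no shift beyond the scatter is expected. The estimated step is a step that the limit leaves unreadable from compound 2 to compound 3. Compound 3 is expected to give about 250000 nM, within 100000 nM to 600000 nM, most likely again only a limit.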

Compound 3, half-maximal inhibitory concentration: 55000 nM
For compound 3 the middle estimate is 4.5-fold (0.66 log units) above the measured one; measured number outside the range, below it.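

For the compounds shown here, this aromatic carbon turns out to respond to the atom it carries: in this assay, iodo in place of bromo gives an at least 3.6-fold lower number from compound 2 to compound 3 (0.56 log units; beyond the scatter), the first readable step here. The 4-iodophenyl group also stands apart from 3,4-dimethoxyphenyl, with an at least 3.6-fold lower number from compound 1 to compound 3 (0.56 log units; beyond the scatter). Both steps are minimum sizes, not exact ones, because the comparison starts from a limit: the limit of > 200000 nM in this assay, at which 2 of the 3 values shown sit.

Still open, from the compounds shown here alone, is how chloro or an amine on this same aromatic carbon would read in this assay. That leaves unsettled whether the lower number belongs to iodo alone.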